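Chloro to bromo on compound 3

The source may hold more compounds than are shown below. What is called first, only, known or untested is meant among the compounds shown, and "the series" means these compounds.

- compound 1 `Cn1ccc2c(Oc3ccc(NC(=O)c4cc5cccnc5n(-c5ccc(Br)cc5)c4=O)cc3F)ncnc21`: 59400 nM
- compound 2 `O=C(Nc1ccc(Oc2ncnc3[nH]ccc23)c(F)c1)c1cc2cccnc2n(-c2ccccc2)c1=O`: 45000 nM
- compound 3 `O=C(Nc1ccc(Oc2ncnc3[nH]ccc23)c(F)c1)c1cc2cccnc2n(-c2ccc(Cl)cc2)c1=O`: 45000 nM

In a functional assay on MCF7 cells (Homo sapiens) for cytotoxicity, read by MTT assay, with a stated time of 72 h (a lower number here means a stronger inhibitor, a higher number a weaker inhibitor), compound 3 stands level with compound 2, and compound 1 lies within the scatter of compound 3. Compound 4 `O=C(Nc1ccc(Oc2ncnc3[nH]ccc23)c(F)c1)c1cc2cccnc2n(-c2ccc(Br)cc2)c1=O` differs from compound 3 by bromo in place of chloro on an aromatic carbon. For the measured compounds named here, only one measured step bears on this change, and it is a substitution at the same place: no change at the digits printed from compound 2 to compound 3 (within the scatter). Compound 1 also carries a 4-bromophenyl group, differs elsewhere, and gives 59400 nM. No shift beyond the scatter is therefore expected in this assay, and the expected change is a 1.1-fold higher number from compound 3 to compound 4 (0.03 log units; within the scatter). Compound 4 is estimated at 48000 nM, with an expected range of 25000 nM to 85000 nM.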

Compound 4, half-maximal inhibitory concentration: 27000 nM
Compound 4: the middle estimate sits 1.8-fold (0.25 log units) above what was measured; the range from low to high includes it.
By their numbers in this assay, from the lowest: compounds 4, 2, 3 and 1 (each within the scatter of the next, the first and the last beyond it).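

In this assay, for the compounds shown here, bromo in place of chloro gives a 1.7-fold lower number from compound 3 to compound 4 (0.22 log units; within the scatter), and bromo in place of hydrogen gives a 1.7-fold lower number from compound 2 to compound 4 (0.22 log units; within the scatter), so no halogen step at this position, para to a large group, passes the scatter. With the 4-bromophenyl group held constant, hydrogen in place of methyl on the aromatic nitrogen gives a 2.2-fold lower number from compound 1 to compound 4 (0.34 log units; beyond the scatter), a modest step beyond the scatter. No measurement shown explains these steps. Open, as far as these compounds go, is whether an amine or a carboxylic acid at this position would move the number beyond the scatter, and whether methyl on that nitrogen gives a similar step alongside phenyl or 4-chlorophenyl.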